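A few compounds are considered here, and "the series" means these few. Any claim that something is new, unique, unknown or untested is made for them only; others in the source may bear on it.

Measured so far in a functional assay on PC-3 cells (Homo sapiens) for cytotoxicity, read by MTT assay, with a stated time of 48 h; on this read-out lower numbers stand for stronger inhibition and higher numbers for weaker inhibition:
compound 1 `CNCC(=O)N1N=C(c2cc3ccccc3oc2=O)CC1c1ccccc1` gives 2300 nM
compound 2 `CC1CCCN(CC(=O)N2N=C(c3cc4ccccc4oc3=O)CC2c2ccccc2)C1` gives 28300 nM

Among these two numbers compound 2 stands highest, its nearest neighbour being compound 1. Among the measured compounds shown here, the single measured step, a 12-fold higher number from compound 1 to compound 2 (1.09 log units; beyond the scatter), is the only guide available; it describes a different exchange at the same place and so bears on the present question only indirectly. Compound 3 `CCN(CC)C1CCN(CC(=O)N2N=C(c3cc4ccccc4oc3=O)CC2c2ccccc2)CC1` carries 4-(diethylamino)piperidin-1-yl in place of 3-methylpiperidin-1-yl on a saturated chain carbon bound to a carbonyl carbon. For the measured compounds named here, no measured pair reports this particular change, and there is no second step to show whether enlarging the group at this position moves the numbers further or pulls them back. The estimate therefore stays close to compound 2 with a wide range. Compound 3 is expected to give about 20000 nM, with a range from 5000 nM to 60000 nM. The expected step of a 1.4-fold lower number from compound 2 to compound 3 (0.15 log units; within the scatter) is small and not beyond the scatter.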

Compound 3, half-maximal inhibitory concentration: 26100 nM
Compound 3: the middle estimate sits 1.3-fold (0.12 log units) below what was measured, and the stated range covers the measured number.
By their numbers in this assay, from the lowest: compound 1; then compounds 3 and 2 (each within the scatter of the next).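

In this assay the exchange of 3-methylpiperidin-1-yl for 4-(diethylamino)piperidin-1-yl on the saturated chain carbon bound to a carbonyl carbon gives a 1.1-fold lower number from compound 2 to compound 3 (0.04 log units; within the scatter) and so does not separate the two groups, despite the added diethylamino substituent and second nitrogen. Against methylamino, the entering group gives an 11-fold higher number from compound 1 to compound 3 (1.05 log units; beyond the scatter) in the same direction as compound 2, so both piperidin-1-yl groups shown here stand apart from the methylamino group of compound 1. No measured evidence accounts for these numbers.

On these data alone, whether the higher numbers go with the six-membered ring itself or with its substituents stays open. Unsubstituted piperidin-1-yl, morpholin-4-yl and an acyclic dimethylamino group at this place would help to separate these two readings.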